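Aryl for Hexyl on the Amine Nitrogen: Estimating Compound 4

The source may report more compounds than this note shows. Statements on the series, on what has been measured and on what is new or still open speak of the compounds shown alone.

Measured so far:
- compound 1 `CCCCCCNc1nc(SCc2ccc(C(F)(F)F)cc2)nc2ccccc12`: 20200 nM
- compound 3 `FC(F)(F)c1ccc(CSc2nc(Nc3cccc(C(F)(F)F)c3)c3ccccc3n2)cc1`: 11100 nM
- compound 2 `FC(F)(F)c1ccc(CSc2nc(Nc3ccccc3C(F)(F)F)c3ccccc3n2)cc1`: reported only as a limit, > 50000 nM

In a functional assay on MDA-MB-231 cells (Homo sapiens) for cytotoxicity, read by MTT assay, with a stated time of 72 h (on this read-out lower numbers stand for stronger inhibition and higher numbers for weaker inhibition), compound 1 gives 20200 nM. Compound 3 gives 11100 nM, and the step of a 1.8-fold lower number from compound 1 to compound 3 (0.26 log units; within the scatter) stays within the scatter. Compound 2 yields only a limit, > 50000 nM, so the step of an at least 2.4-fold higher number from compound 1 to compound 2 (0.39 log units; beyond the scatter) points to weaker inhibition, as does an at least 4.5-fold lower number from compound 2 to compound 3 (0.65 log units; beyond the scatter) in reverse; the limit is described by the limit of > 50000 nM in this assay, at which 1 of the 3 values shown sits.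

Compound 4 `Cc1ccc(Nc2nc(SCc3ccc(C(F)(F)F)cc3)nc3ccccc23)cc1` differs from compound 1 by 4-methylphenyl in place of hexyl on a nitrogen on an aromatic ring. This is again an aryl group in place of the hexyl chain, like the two measured steps, which gave either no change beyond the scatter or a modest worsening. The expected step is therefore small: a 1.3-fold lower number from compound 1 to compound 4 (0.13 log units; within the scatter). Compound 4 is estimated at 15000 nM, within 5000 nM to 45000 nM.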

Compound 4, half-maximal inhibitory concentration: > 50000 nM
Compound 4: only a limit was reported (the forecaster's own chance of this, stated with the estimate: 15%); middle value at least 3.3-fold (0.52 log units) away from the limit.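

In this assay compound 4 is reported only as a limit, and it shares that limit with compound 2: the limit of > 50000 nM in this assay, at which 2 of the 4 values shown sit.

Putting an aryl group on this nitrogen is thus not a neutral swap for hexyl: the data show an at least 2.4-fold higher number from compound 1 to compound 4 (0.39 log units; beyond the scatter) and an at least 4.5-fold higher number from compound 3 to compound 4 (0.65 log units; beyond the scatter), so among these three aryl compounds only the 3-(trifluoromethyl)phenyl of compound 3 stays within the scatter of hexyl. The step between compound 2 and compound 4 cannot be read, since both are limits.

Compounds 3 and 4 differ in both the group on the ring and where it sits, so these two effects remain unseparated. As far as these compounds go, how an unsubstituted phenyl or a longer chain would behave on this nitrogen also stays open.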